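The compounds below may be only part of what the source reports. "The series", "measured", "known", "first", "only" and "open" are said of these compounds alone.

Of the compounds shown here, three built on a shared core have been tested in a functional assay on NCI-H322M cells (Homo sapiens) for cytotoxicity, read by sulforhodamine B assay, with a stated time of 48 h; on this read-out lower numbers stand for stronger inhibition of growth and higher numbers for weaker inhibition of growth. Compound 1 `ClCc1ccccc1Cn1cnc2c(Cl)nc(Cl)nc21` gives 1730 nM, compound 2 `ClCc1cccc(Cn2cnc3c(Cl)nc(Cl)nc32)c1` gives 2290 nM, and compound 3 `Nc1nc(Cl)c2ncn(Cc3ccccc3CCl)c2n1` gives 12300 nM. Compound 1 and compound 2 contain the same atoms joined differently; the difference between their two cores is not broken down here. Compound 3 arises from compound 1 by amino in place of chloro on an aromatic carbon, a change that produced a 7.1-fold higher number from compound 1 to compound 3 (0.85 log units; beyond the scatter). Compound 4 `Nc1nc(Cl)c2ncn(Cc3cccc(CCl)c3)c2n1` has not yet been measured; it arises from compound 2 by amino in place of chloro on an aromatic carbon, the same change at the same place. Because that change earlier gave a 7.1-fold higher number from compound 1 to compound 3 (0.85 log units; beyond the scatter), compound 4 is expected to show a 7.0-fold higher number from compound 2 to compound 4 (0.84 log units; beyond the scatter) in this assay. Compound 4 is therefore estimated at 16000 nM, with a likely range from 6000 nM to 40000 nM.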

Compound 4, concentration for 50% growth inhibition: 10500 nM
The estimate for compound 4 lay 1.5-fold (0.18 log units) above the measured number; measured number inside the range.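

Replacing chloro with amino on the aromatic carbon between two ring nitrogen atoms again weakened growth inhibition in this assay, with a 4.6-fold higher number from compound 2 to compound 4 (0.66 log units; beyond the scatter) on the core of compound 2. Set beside the earlier step, the change carried across both cores in direction, and its size agreed within the scatter: the same change on two cores in this assay, a 7.1-fold higher number (0.85 log units; beyond the scatter) from compound 1 to compound 3 and a 4.6-fold higher number (0.66 log units; beyond the scatter) from compound 2 to compound 4, 1.6-fold (0.19 log units) apart, within the scatter of two such steps. These two pairs show that the effect held on these two cores in this one cell line, but they do not show why it arises or whether it would hold on any other core.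

The compounds shown leave open how other groups at this place would compare with chloro and amino. A methoxy or dimethylamino group, for example, could follow either one or neither.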